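Removing the ring fluorine from the pendant aryl of compound 1

The compounds below may be only part of what the source reports. "The series", "measured", "known", "first", "only" and "open" are said of these compounds alone.

Measured compounds:
compound 1, `COc1cc2c(Oc3ccc(NC(=O)c4cc(-c5ccccc5F)ccn4)cc3F)ccnc2cc1OCCCN1CCCCC1`, 130 nM
compound 2, `COc1cc2c(Oc3ccc(NC(=O)c4cc(-c5ccccc5F)ccn4)cc3F)ccnc2cc1OCCCN1CCN(C)CC1`, 140 nM
compound 3, `COc1cc2c(Oc3ccc(NC(=O)c4cc(-c5ccccc5F)ccn4)cc3F)ccnc2cc1OCCCN1CCCC1`, 140 nM

These three share one core and differ only in the cyclic amine at the end of the chain attached to the aromatic oxygen. In a functional assay on NCI-H460 cells (Homo sapiens) for cytotoxicity, read by MTT assay, with a stated time of 72 h (on this read-out higher numbers stand for weaker inhibition and lower numbers for stronger inhibition), compound 1 gives the lowest of the three numbers, but its steps to the others, a 1.1-fold higher number from compound 1 to compound 2 (0.03 log units; within the scatter) and a 1.1-fold higher number from compound 1 to compound 3 (0.03 log units; within the scatter), both lie within the scatter, as does no change at the digits printed from compound 2 to compound 3 (within the scatter), so no ordering among them can be claimed.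

Compound 4, `COc1cc2c(Oc3ccc(NC(=O)c4cc(-c5ccccc5)ccn4)cc3F)ccnc2cc1OCCCN1CCCCC1`, keeps the piperidinyl chain of compound 1 and changes the pendant aryl instead: hydrogen in place of fluoro on an aromatic carbon. Among the compounds with values here, none of the measured steps touches this part of the molecule; they all concern the amine on the chain and were all within the scatter. Within the data shown here, with no step bearing on the fluoro-to-hydrogen change, the expectation for compound 4 in this assay rests on compound 1 alone, and the step of a 1.2-fold higher number from compound 1 to compound 4 (0.09 log units; within the scatter) is estimated to stay within the scatter. Compound 4 is therefore expected to give about 160 nM, in the range 60 nM to 450 nM.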

Compound 4, half-maximal inhibitory concentration: 120 nM
Compound 4: the middle estimate sits 1.3-fold (0.12 log units) above what was measured; low and high end bracket the measured number.
By their numbers in this assay, from the lowest: compounds 4, 1, 2 and 3 (each within the scatter of the next).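

Within the data shown here, the 2-fluorophenyl to phenyl change is the first measured step at this part of the molecule, and in this assay it reads as a 1.1-fold lower number from compound 1 to compound 4 (0.03 log units; within the scatter) and so stays within the scatter. Among these compounds, on the piperidinyl chain of compound 1, then, hydrogen can stand in place of the fluoro, ortho to a large group, without a change that can be told from the scatter, and the pendant aryl joins the amine at the end of the chain as a place where no step in this set rises above it. No evidence in hand bears on the reason for this result.

The compounds shown leave open whether the same step would hold with the 4-methylpiperazin-1-yl or pyrrolidin-1-yl chain. They also leave open whether a larger group on that aromatic carbon, such as methoxy, a carboxylic acid or an amine, would move the number beyond the scatter.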